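The source may report more compounds than this note shows. Statements on the series, on what has been measured and on what is new or still open speak of the compounds shown alone.

Compound 3 `COc1ccc2[nH]c(=O)c(-c3nc4cc(Cl)ccc4[nH]3)cc2c1` stands at the ceiling of an ADME assay on L02 cells (Homo sapiens) for cytotoxicity, read by MTT assay, with a stated time of 48 h; on this read-out lower numbers stand for stronger inhibition and higher numbers for weaker inhibition: in that assay compound 3 gives > 100000 nM, which is a limit of the assay and not a number. Compound 1 `O=c1[nH]c2ccccc2cc1-c1nc2cc(F)ccc2[nH]1` likewise gives > 100000 nM, a limit. Compound 2 `O=c1[nH]c2ccccc2cc1-c1nc2cc([N+](=O)[O-])ccc2[nH]1` gives > 100000 nM, also a limit. The step from compound 1 to compound 2, a step that the two limits leave unreadable from compound 1 to compound 2, is thus not readable, and all three values rest at the limit of > 100000 nM in this assay, at which 3 of the 3 values shown sit. Compound 4 `COc1ccc2[nH]c(=O)c(-c3nc4ccccc4[nH]3)cc2c1` differs from compound 3 by hydrogen in place of chloro on an aromatic carbon. No measured step bears on this change, and no shown step has a readable size, so no shift beyond the scatter is expected in this assay. Compound 4 is therefore expected to give 100000 nM, between 50000 nM and 300000 nM, an expected step of a number no higher from compound 3 to compound 4 (the limit leaves the size open).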

Compound 4, half-maximal inhibitory concentration: > 100000 nM
Compound 4: a limit, no number (the forecaster's own chance of this, stated with the estimate: 85%); the middle value lies on the limit itself.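

Compound 3 and compound 4 both give only a limit, and the step between them cannot be read. The compounds shown leave open what actual number any of them would give in this assay and whether swapping chloro for hydrogen changes it.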